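Swapping a Methyl for Bromo on the Amide Chain

The source may report more compounds than this note shows. Statements on the series, on what has been measured and on what is new or still open speak of the compounds shown alone.

Three compounds sharing one core have been measured in a functional assay on MGC-803 cells (Homo sapiens) for inhibition, read by MTT assay, with a stated time of 48 h; a lower number here means a stronger inhibitor, a higher number a weaker inhibitor:

Compound 1, `CCCCC(=O)N(Cc1ccc(OC)c(O)c1)c1cc(OC)c(OC)c(OC)c1`, gives 66 nM.
Compound 2, `C/C=C/C=C/C(=O)N(Cc1ccc(OC)c(O)c1)c1cc(OC)c(OC)c(OC)c1`, gives 140 nM.
Compound 3, `CCC(=O)N(Cc1ccc(OC)c(O)c1)c1cc(OC)c(OC)c(OC)c1`, gives 50 nM.

Compound 3 has the lowest number of the three, but its gap to compound 1, a 1.3-fold lower number from compound 1 to compound 3 (0.12 log units; within the scatter), lies within the scatter, so the two cannot be told apart. Only compound 2 stands clearly apart: a 2.8-fold lower number from compound 2 to compound 3 (0.45 log units; beyond the scatter), and a 2.1-fold higher number from compound 1 to compound 2 (0.33 log units; beyond the scatter), both modest.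

Compound 4, `COc1ccc(CN(C(=O)CBr)c2cc(OC)c(OC)c(OC)c2)cc1O`, differs from compound 3 in one place: bromo in place of methyl on a saturated chain carbon bound to a carbonyl carbon. Put otherwise, propanoyl becomes (bromomethyl)carbonyl.

Going by the values given here, no measured step exchanges a carbon for a halogen on this chain. The steps that come closest alter the same chain: a 1.3-fold lower number from compound 1 to compound 3 (0.12 log units; within the scatter), within the scatter, and a 2.8-fold lower number from compound 2 to compound 3 (0.45 log units; beyond the scatter), modest. All three chain variants stay in one narrow band. The chain therefore seems to tolerate change, and a step in this assay of no more than modest size in either direction is expected here.

Compound 4 is estimated at 60 nM, with a range from 25 nM to 150 nM. That estimate corresponds to a step of a 1.2-fold higher number from compound 3 to compound 4 (0.08 log units; within the scatter), expected to fall within the scatter.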

Compound 4, half-maximal inhibitory concentration: 140 nM
Compound 4: the middle estimate sits 2.3-fold (0.37 log units) below what was measured, within the range that was stated.
By their numbers in this assay, from the lowest: compounds 3 and 1 (each within the scatter of the next); then compounds 2 and 4 (each within the scatter of the next).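

In this assay, going by these compounds alone, this position proves sensitive to a single-atom exchange: bromo in place of methyl gives a 2.8-fold higher number from compound 3 to compound 4 (0.45 log units; beyond the scatter) as a step beyond the scatter, so this chain does not tolerate every change, even though the steps among the earlier compounds stayed modest or smaller. The comparison with a larger chain points the same way, with a 2.1-fold higher number from compound 1 to compound 4 (0.33 log units; beyond the scatter) also beyond the scatter, while no change at the digits printed from compound 2 to compound 4 (within the scatter) shows that bromomethyl and penta-1,3-dien-1-yl, two very different groups on the carbonyl carbon, cannot be told apart in this assay. Nothing available here accounts for these steps.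

From the compounds shown here alone, what stays open is whether the loss belongs to bromo alone or to halogens on this carbon in general, a question that chloro or fluoro in the same place could help settle. A hydroxyl or an amine on this carbon would further show how the number responds when the methyl gives way to a group that is neither a carbon chain nor a halogen.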